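Swapping an aromatic ring on a weakly active pyrazole acid

This account rests on a few compounds, and the source may have more. Where it says the series, first, only, none or still open, it means among the compounds named here.

Measured so far:
compound 1, `COc1cccc(-c2c(C)nn(-c3nc(-c4ccc(Cl)c(Cl)c4)c(SC(C)C)s3)c2C(=O)O)c1`: 14000 nM
compound 2, `COC(=O)c1c(Cc2ccccc2[N+](=O)[O-])c(C)nn1-c1nc(-c2ccc(Cl)c(Cl)c2)cs1`: 377000 nM

In a functional assay on BJAB cells (Homo sapiens) for antiproliferative activity, with a stated time of 4 days (on this read-out lower numbers stand for an effect already at smaller amounts and higher numbers for an effect only at larger amounts of compound), compound 1 gives 14000 nM, the lowest of the two numbers measured. Compound 2 differs from it in several places at once, and in this assay compound 2 gives 377000 nM, a gap well beyond the scatter; since the two differ in more than one place, the data do not tell which change matters.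

Compound 3, `Cc1nn(-c2nc(-c3ccc(Cl)c(Cl)c3)c(SC(C)C)s2)c(C(=O)O)c1-c1cnccn1`, has not been measured. It differs from compound 1 in a single place: pyrazin-2-yl in place of 3-methoxyphenyl on an aromatic carbon, on an aromatic carbon of a five-membered aromatic ring with 2 nitrogen. Within the data shown here, no measured pair shows what such a swap does here, so no firm direction can be read from the data. A modest step in either direction, or none beyond the scatter, is expected from compound 1; the estimated change is a 1.4-fold higher number from compound 1 to compound 3 (0.15 log units; within the scatter). For compound 3 the estimate in this assay is 20000 nM, with a range from 5000 nM to 80000 nM.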

Compound 3, half-maximal effective concentration: 14000 nM
The estimate for compound 3 lay 1.4-fold (0.15 log units) above the measured number, within the range that was stated.
By their numbers in this assay, from the lowest: compounds 1 and 3 (each within the scatter of the next); then compound 2.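

In this assay, among these compounds, placing pyrazin-2-yl in place of 3-methoxyphenyl gives no change at the digits printed from compound 1 to compound 3 (within the scatter), the first comparison here between compounds that differ in one place. At this position, on an aromatic carbon of the five-membered ring, a group with fewer heavy atoms and one more hydrogen-bond acceptor therefore leaves the number within the scatter, so neither the all-carbon ring nor its methoxy group is needed to keep this weak activity. No measurement is available that would explain this result.

Going by these compounds, whether a group of another kind at this position, such as an amine or a longer carbon chain, would shift the number beyond the scatter remains open. A single swap also cannot show whether any aromatic ring is needed here at all.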